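The compounds below may be only part of what the source reports. "The series", "measured", "known", "first", "only" and "open" are said of these compounds alone.

Measured so far in an ADME assay on a cell-free system (plasma, Mus musculus) for metabolic stability, tested at 1 uM; on this read-out lower numbers stand for a shorter-lived compound and higher numbers for a longer-lived compound:
- Compound 1 `C=CC(=O)NC1CCN(S(=O)(=O)c2ccc(C(=O)NCc3ccccc3)cc2)CC1`: > 6 h, a limit.
- Compound 2 `C=CC(=O)NC1CCN(S(=O)(=O)c2ccc(C(=O)N[C@@H]3C[C@H]3c3ccccc3)cc2)CC1`: > 6 h, a limit.
- Compound 3 `C=CC(=O)NC1CCN(S(=O)(=O)c2ccc(C(=O)NCCC3CCCCC3)cc2)CC1`: > 6 h, a limit.

Compound 3 stands at > 6 h, and this is a limit of the assay, not a number. It therefore shows no exact half-life from which to count onward.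

The next compound, compound 4 `C=CC(=O)NC1CCN(S(=O)(=O)c2ccc(C(=O)NC3CCCc4ccccc43)cc2)CC1`, differs from compound 3 in one place: 1,2,3,4-tetrahydronaphthalen-1-yl in place of 2-cyclohexylethyl on an amide-type nitrogen.

For the measured compounds named here, three measured steps bear on this change, since each alters the group carried by that nitrogen: a step that the two limits leave unreadable from compound 1 to compound 2, a step that the two limits leave unreadable from compound 1 to compound 3 and a step that the two limits leave unreadable from compound 2 to compound 3. None of them has a readable size, so no measured size can be carried over to the new step. What they do show is a shared result across benzyl, 2-phenylcyclopropyl and 2-cyclohexylethyl: the limit of > 6 h in this assay, at which 3 of the 3 values shown sit.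

On that basis, no step beyond the scatter is expected in this assay, in either direction, and compound 4 will most likely report the same limit. The estimated change is a step that the limit leaves unreadable from compound 3 to compound 4. The estimate for compound 4 is 8 h, with an expected range from 5 h to 16 h.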

Compound 4, half-life: > 6 h
Compound 4 was reported as a limit; the forecaster's own chance of this, stated with the estimate: 85%; the middle value lies beyond the limit too.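

In this assay compound 4 gives > 6 h, which is a limit of the assay and not a number. No step from compound 1, compound 2 or compound 3 to compound 4 can be read, as all four compounds share one result: the limit of > 6 h in this assay, at which 4 of the 4 values shown sit.

The compounds shown leave open the actual half-life of each one, and so whether changing the group on the amide-type nitrogen alters it at all.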